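Replacing the 4-hydroxyphenyl group of compound 2

A few compounds are considered here, and "the series" means these few. Any claim that something is new, unique, unknown or untested is made for them only; others in the source may bear on it.

Compound 1 `COc1ccc(-c2nc(N/N=C/c3ccc(Br)cc3)[nH]c(=O)c2C#N)cc1`: 2.45
Compound 2 `COc1ccc(-c2nc(N/N=C/c3ccc(O)cc3)[nH]c(=O)c2C#N)cc1`: 1.27

In a physicochemical assay for lipophilicity (a lower number here means a more polar compound, a higher number a more lipophilic compound), compound 2 holds the lower of the two numbers, at 1.27. Compound 3 `COc1ccc(-c2nc(N/N=C/c3cccc(F)c3)[nH]c(=O)c2C#N)cc1` differs from it by 3-fluorophenyl in place of 4-hydroxyphenyl on a carbon with a double bond to nitrogen. Within the data shown here, one measured step bears on this change: a number 1.18 log units lower from compound 1 to compound 2 (beyond the scatter), with hydroxy in place of bromo on an aromatic carbon. Among the measured compounds shown here, compound 3 also lacks the hydroxy group, but no measured compound carries fluoro, so a rise smaller than that step is expected in this assay. The expected step is a number 0.78 log units higher from compound 2 to compound 3 (beyond the scatter). The estimated value for compound 3 is 2.05, in a range from 1.65 to 2.45.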

Compound 3, partition coefficient: 2.13
Compound 3: the middle estimate sits 0.08 log units below what was measured; the range from low to high includes it.
By their numbers in this assay, from the lowest: compound 2; then compound 3; then compound 1.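

In this assay, the place on the carbon with a double bond to nitrogen now shows a second replacement of 4-hydroxyphenyl, with a number 0.86 log units higher from compound 2 to compound 3 (beyond the scatter). The two halogen-bearing groups do not read alike here, as 3-fluorophenyl in place of 4-bromophenyl gives a number 0.32 log units lower from compound 1 to compound 3 (beyond the scatter), which leaves compound 3 between compound 2 and compound 1. No measurement is available that gives a cause for either step. The compounds shown do not separate the change of halogen from the shift from 4-bromophenyl to a 3-substituted phenyl. Where a 4-aminophenyl or 4-carboxyphenyl group would stand in this assay also remains open.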